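A few compounds are considered here, and "the series" means these few. Any claim that something is new, unique, unknown or untested is made for them only; others in the source may bear on it.

Working notes on the series. Compound 2 `COc1cccc(C(C)Sc2nc3c(cnn3C)c(=O)n2-c2ccccc2)c1` sits second highest of the three numbers in an assay on isolated protein for inhibition of Retinaldehyde dehydrogenase 3 (Homo sapiens) (a higher number here means a weaker inhibitor, a lower number a stronger inhibitor), with 174 nM. Compound 1 `Cn1ncc2c(=O)n(-c3ccccc3)c(SCc3cccc(F)c3)cc21` gives 140 nM, a gap to compound 2 that lies within the scatter. Compound 3 `Cn1ncc2c(=O)n(-c3ccccc3)c(CNc3cccc(F)c3)nc21` gives 1050 nM, the highest of the three and beyond the scatter from compound 2. Among the compounds with values here, no pair differing in a single place has been measured, so no single-step effect is known.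

Compound 4 `CC(Sc1nc2c(cnn2C)c(=O)n1-c1ccccc1)c1ccccc1` is next: hydrogen in place of methoxy on an aromatic carbon, (hydrogen in place of methoxy on an aromatic carbon). Within the data shown here, with no matched step to rest on, a small weakening is expected, most likely not beyond the scatter; the step from compound 2 to compound 4 is estimated at a 1.5-fold higher number from compound 2 to compound 4 (0.17 log units; within the scatter). For compound 4 the expected value is 260 nM, within 110 nM to 620 nM.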

Compound 4, half-maximal inhibitory concentration: 73 nM
Estimate against measurement, compound 4: 3.6-fold (0.55 log units) above; measured number below the stated range.
By their numbers in this assay, from the lowest: compounds 4, 1 and 2 (each within the scatter of the next, the first and the last beyond it); then compound 3.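

Within the data shown here, this is the first single-place step: in this assay, hydrogen in place of methoxy on an aromatic carbon gives a 2.4-fold lower number from compound 2 to compound 4 (0.38 log units; beyond the scatter). At this position, the methoxy is therefore not required for inhibition, and the unsubstituted phenyl gives the lower number. No measurement at hand bears on the reason for this step.

As far as these compounds go, it remains open whether the lower number is specific to losing methoxy or whether other groups on this aromatic carbon behave alike. A hydroxyl, an amine or a carboxylic acid there would test this.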